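Methylamino for methylsulfanyl on the fused core

This account rests on a few compounds, and the source may have more. Where it says the series, first, only, none or still open, it means among the compounds named here.

Compound 1 `CSc1nn2cccnc2c1S(=O)(=O)c1ccccc1` gives 115 nM in a functional assay on HEK293 cells for antagonist activity at 5-hydroxytryptamine receptor 6 (Homo sapiens), read by cAMP accumulation, with a stated time of 2 h; a lower number here means a stronger inhibitor, a higher number a weaker inhibitor. Compound 2 `CNc1nn2cccnc2c1S(=O)(=O)c1ccccc1` gives 3.89 nM in this assay; the step of a 30-fold lower number from compound 1 to compound 2 (1.47 log units; beyond the scatter) comes from methylamino in place of methylsulfanyl on an aromatic carbon. Compound 3 `CSc1nn2c(C)cc(C)nc2c1S(=O)(=O)c1ccc(O)cc1` gives 3.98 nM in this assay; how its core differs from that of compound 1 is not broken down here, and its value and that of compound 2 lie within the usual scatter. Compound 4 `CNc1nn2c(C)cc(C)nc2c1S(=O)(=O)c1ccc(O)cc1` is not yet measured and differs from compound 3 by methylamino in place of methylsulfanyl on an aromatic carbon. This is the same kind of change as from compound 1 to compound 2, though the earlier place reads next to the ring atom that bears a group of 9 heavy atoms and the present one next to the ring atom that bears a large group. For compound 4 the step of a 13-fold lower number from compound 3 to compound 4 (1.12 log units; beyond the scatter) is expected in this assay, smaller than the earlier one, resting on compound 1 and the measured 30-fold lower number from compound 1 to compound 2 (1.47 log units; beyond the scatter) with a single precedent. Compound 4 is thus estimated at 0.3 nM, expected between 0.06 nM and 1.5 nM.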

Compound 4, inhibition constant: 2 nM
The estimate for compound 4 lay 6.7-fold (0.82 log units) below the measured number; measured number outside the range, above it.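

On the core of compound 3 in this assay, methylamino in place of methylsulfanyl gives a 2.0-fold lower number from compound 3 to compound 4 (0.30 log units; within the scatter). The size of the step does not carry over from the core of compound 1 to the core of compound 3: the same change on two cores in this assay, a 30-fold lower number (1.47 log units; beyond the scatter) from compound 1 to compound 2 and a 2.0-fold lower number (0.30 log units; within the scatter) from compound 3 to compound 4, 15-fold (1.17 log units) apart, beyond the scatter of two such steps

For the compounds shown here, with only two pairs, and with cores that differ in more than one place, these data do not show which core difference goes with the gap, nor how the step would read on any other core.

Open, going by these compounds, is how the step reads on a core with only the two ring methyl groups, or with only the hydroxyl on the phenyl group. Also open, on these data alone, is whether a dimethylamino or ethylamino group in this place follows methylamino on either core.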